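The source may report more compounds than this note shows. Statements on the series, on what has been measured and on what is new or still open speak of the compounds shown alone.

Compound 1 `Cc1ccc(NS(=O)(=O)c2ccc(N3CCNC3=O)cc2)cc1C`: 230 nM
Compound 2 `Cc1ccc(C)c(NS(=O)(=O)c2ccc(N3CCNC3=O)cc2)c1`: 46 nM

Both compounds were tested in a functional assay on HT-29 cells (Homo sapiens) for antiproliferative activity, read by sulforhodamine B assay, with a stated time of 48 h; a higher number here means a weaker inhibitor, a lower number a stronger inhibitor. Among the compounds with values here, compound 2, at 46 nM, has the lower number of the two, so it is the stronger inhibitor, and compound 1 is its only neighbour. The next compound, compound 3 `COc1ccccc1NS(=O)(=O)c1ccc(N2CCNC2=O)cc1`, places 2-methoxyphenyl in place of 2,5-dimethylphenyl on a sulfonamide nitrogen, and the rest of the molecule stays the same: 2-methoxyphenyl in place of 2,5-dimethylphenyl on a sulfonamide nitrogen.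

Within the data shown here, only one measured step bears on this change: a 5.0-fold lower number from compound 1 to compound 2 (0.70 log units; beyond the scatter). That step swapped one group for another at the same place and went beyond the scatter, so a change here can move the number. Among the measured compounds shown here, it is thin evidence, though, since no measured compound yet carries a methoxy group. Starting from the lower of the two values, a step of similar size is expected in this assay, towards a higher number, with real uncertainty about its direction. The expected change is a 4.3-fold higher number from compound 2 to compound 3 (0.64 log units; beyond the scatter). For compound 3 the estimated value is 200 nM, with an expected range of 40 nM to 1000 nM.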

Compound 3, half-maximal inhibitory concentration: 550 nM
The estimate for compound 3 lay 2.8-fold (0.44 log units) below the measured number; low and high end bracket the measured number.
By their numbers in this assay, from the lowest: compound 2; then compound 1; then compound 3.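

Within this assay, the group on the sulfonamide nitrogen now proves able to move the number by more than the dimethylphenyl swap did: 2-methoxyphenyl in place of 2,5-dimethylphenyl gives a 12-fold higher number from compound 2 to compound 3 (1.08 log units; beyond the scatter), a step rated large where the earlier one was rated modest. Compared with the other dimethyl compound, the same group gives a 2.4-fold higher number from compound 1 to compound 3 (0.38 log units; beyond the scatter), so in this small set 2-methoxyphenyl ranks behind both dimethylphenyl groups, even though the group entering has the same count of 8 heavy atoms as the one leaving, with one oxygen and one hydrogen-bond acceptor as the counted differences. Nothing measured on these compounds offers an explanation for this loss of activity.

The compounds shown leave open whether the higher number of compound 3 belongs to the methoxy group itself or to the absence of the two methyl groups, and a 2-methylphenyl group at this place would help separate those two readings. How a 2-chlorophenyl or 2-aminophenyl group on the sulfonamide nitrogen would compare also remains an open question.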